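This account rests on a few compounds, and the source may have more. Where it says the series, first, only, none or still open, it means among the compounds named here.

Compounds measured in an assay for inhibition of Thromboxane-A synthase (Homo sapiens), using microsomes; a lower number here means a stronger inhibitor, a higher number a weaker inhibitor:
compound 1, `O=C(O)CC/C=C\CC1COC(c2cccnc2)OC1c1cccnc1`, 220 nM;
compound 2, `O=C(O)CC/C=C\CC1COC(c2cccs2)OC1c1cccnc1`, 71 nM;
compound 3, `CC(C)(Oc1ccccc1[N+](=O)[O-])C1OCC(C/C=C\CCC(=O)O)C(c2cccnc2)O1`, < 10 nM.

Compound 2 has the lowest of the two numbers reported in this assay. For the measured compounds named here, its nearest neighbour is compound 1, and the step of a 3.1-fold lower number from compound 1 to compound 2 (0.49 log units; beyond the scatter) is the only single-point change measured here. Going by the values given here, compound 3 gives only a limit in this assay, not a number, and it is the one value that sits at the limit of < 10 nM in this assay, at which 1 of the 3 values shown sits.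

Compound 4, `CC(C)(Sc1ccccc1)C1OCC(C/C=C\CCC(=O)O)C(c2cccnc2)O1`, is not yet measured. It differs from compound 2 in one place: a group of 10 heavy atoms (9 carbon, 1 sulfur; one six-membered aromatic ring of carbon only) in place of a group of 5 heavy atoms (4 carbon, 1 sulfur; one five-membered aromatic ring with 1 hetero atom), on a saturated ring carbon. The ring atom that bears the changing group lies between two ring oxygen atoms of the shared core.

The step from compound 1 to compound 2 bears on this change, since it altered the same saturated ring carbon, and it was modest. Compound 3, which carries a larger group at that same carbon, reached the limit of this assay, but it differs from compound 2 in more than one place, so only its value can be noted. On this basis a further modest decrease in the number is expected for compound 4, the step being estimated as a 2.8-fold lower number from compound 2 to compound 4 (0.45 log units; beyond the scatter). Compound 4 is estimated at 25 nM, with a range from 7 nM to 80 nM.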

Compound 4, half-maximal inhibitory concentration: 40 nM
The estimate for compound 4 lay 1.6-fold (0.20 log units) below the measured number, within the range that was stated.
By their numbers in this assay, from the lowest: compounds 4 and 2 (each within the scatter of the next); then compound 1. At a limit, below all of these: compound 3.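

In this assay, the saturated ring carbon between two ring oxygen atoms accepts a group of 10 heavy atoms, with a carbon-only aromatic ring, in place of thiophen-2-yl, and the result is a 1.8-fold lower number from compound 2 to compound 4 (0.25 log units; within the scatter); the earlier compounds had shown only a swap between two aromatic rings of similar size at this carbon. Set against pyridin-3-yl at the same carbon, the larger group gives a 5.5-fold lower number from compound 1 to compound 4 (0.74 log units; beyond the scatter), so the gain over pyridin-3-yl that thiophen-2-yl had shown is kept with the larger group. For the first time the group on the saturated chain carbon can also be read on its own, with phenylsulfanyl in place of 2-nitrophenoxy giving an at least 4.0-fold higher number from compound 3 to compound 4 (0.60 log units; beyond the scatter), and this step rests on a value that is a limit, not a number: the limit of < 10 nM in this assay, at which 1 of the 4 values shown sits.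

What the compounds shown leave open is which part of 2-nitrophenoxy carries that difference, the nitro group or the ether oxygen, as a plain phenoxy group or a phenylsulfanyl group bearing a nitro group would separate the two. Also open, on these data alone, is what the two methyl groups on the chain carbon contribute, which a benzyl group at the ring carbon would begin to address.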